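The compounds below may be only part of what the source reports. "The series", "measured", "known", "first", "only" and "open" are said of these compounds alone.

Compound 1 `Cn1c(=O)c(C(=O)Nc2ccc(F)cc2F)cc2cnc(Nc3ccc4[nH]ccc4c3)nc21` is the starting point. In a functional assay on DU-145 cells (Homo sapiens) for inhibition, read by trypan blue exclusion, with a stated time of 72 h (a higher number here means a weaker inhibitor, a lower number a stronger inhibitor), compound 1 gives 5000 nM. Compound 2 `Cn1c(=O)c(S(=O)(=O)c2ccc(F)cc2)cc2cnc(Nc3ccc4[nH]ncc4c3)nc21` differs from compound 1 in more than one place, and in this assay compound 2 gives 5000 nM, level with compound 1. Compound 3 `Cn1c(=O)c(S(=O)(=O)Nc2ccc(F)cc2)cc2cnc(Nc3ccc4[nH]ccc4c3)nc21` has not yet been measured. It keeps the rest of compound 1 but carries (4-fluorophenyl)sulfamoyl in place of (2,4-difluorophenyl)carbamoyl on an aromatic carbon. Within the data shown here, no measured pair isolates this swap, so the guidance is thin. Among the measured compounds shown here, the one hint is that compound 2, with a different group at this place, still sits at 5000 nM. The expected step of no change at the digits printed from compound 1 to compound 3 (within the scatter) therefore stays within the scatter, in neither direction. For compound 3 the estimated value is 5000 nM, with an expected range from 1500 nM to 15000 nM.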

Compound 3, half-maximal inhibitory concentration: 5000 nM
Compound 3: the middle estimate sits on the measured number at the digits printed; measured number inside the range.
By their numbers in this assay, from the lowest: compounds 1, 2 and 3 (each within the scatter of the next).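

Putting (4-fluorophenyl)sulfamoyl in place of (2,4-difluorophenyl)carbamoyl on this aromatic carbon gives no change at the digits printed from compound 1 to compound 3 (within the scatter) in this assay. Among these compounds, this is the first pair that differs at this position alone, so the flat reading no longer rests on compound 2, which differs from compound 1 in more than one place, although this one swap alters both the linking group and the fluorine count, and those two edits cannot be told apart. No measurement here offers an explanation for this result.

All the compounds shown carry a fluorinated phenyl ring in this group, so it remains open whether a carboxylic acid or a simple amine here would give a value different from that of compound 3, at 5000 nM. Also open, going by these compounds, is whether a longer chain in place of the methyl group would shift the value.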